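Removing the (carboxymethyl)amino group from compound 2

A few compounds are considered here, and "the series" means these few. Any claim that something is new, unique, unknown or untested is made for them only; others in the source may bear on it.

Values measured in (an ADME assay on MRC5 cells (Homo sapiens) for cytotoxicity, read by MTT assay, with a stated time of 72 h; a lower number here means a stronger inhibitor, a higher number a weaker inhibitor):
Compound 1 (`CC(C)(C)C1=CC(=O)C=C(NCCC(=O)O)C1=O`): > 200000 nM (a limit)
Compound 2 (`CC(C)(C)C1=CC(=O)C=C(NCC(=O)O)C1=O`): > 200000 nM (a limit)
Compound 3 (`CC1=CCC[C@H]2[C@](C)(CC3=CC(=O)C(N4CCC[C@H]4C(=O)O)=CC3=O)[C@@H](C)CC[C@]12C`): 96000 nM

Compound 2 is reported only as a limit (> 200000 nM). It sits on (the limit of > 200000 nM in this assay, at which 2 of the 3 values shown sit) and has no number of its own. Compound 3 alone gives a number (96000 nM). Compound 4 (`CC(C)(C)C1=CC(=O)C=CC1=O`) comes from compound 2 through a single change (hydrogen in place of (carboxymethyl)amino on a double-bonded ring carbon). Among the compounds with values here, the one measured step between close relatives is (a step that the two limits leave unreadable from compound 1 to compound 2), and it offers no size to carry over. Within the data shown here, no measured step covers the loss of the (carboxymethyl)amino group, so the expectation rests on the structural change alone and stays wide. Any readable move away from the limit of compound 2 can only run towards a lower number in this assay, meaning a stronger inhibitor, and such a move is expected here. The expected size is (an at least 6.6-fold lower number from compound 2 to compound 4 (0.82 log units; beyond the scatter)). For compound 4 the estimated value is (30000 nM), with an expected range from 8000 nM to 110000 nM.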

Compound 4, half-maximal inhibitory concentration: > 200000 nM
Compound 4 ended at the assay's limit; the forecaster's own chance of this, stated with the estimate: 10%; middle value at least 6.6-fold (0.82 log units) from the limit.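

Compound 1, compound 2 and compound 4 all sit at a limit rather than at a number, so no step among them can be read in this assay: the limit of > 200000 nM in this assay, at which 3 of the 4 values shown sit.

The compounds shown leave open whether hydrogen, (carboxymethyl)amino or (2-carboxyethyl)amino on the shared core makes any difference beyond that limit.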